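This account rests on a few compounds, and the source may have more. Where it says the series, first, only, none or still open, it means among the compounds named here.

Measured in a functional assay on HEL cells (Homo sapiens) for cytotoxicity (a lower number here means that less compound is tolerated, a higher number that more compound is tolerated), all three values being limits:

- Compound 1 `CCCCCCCc1cc2cn([C@H]3C[C@H](O)[C@@H](CO)O3)c(=O)nc2o1`: > 50000 nM
- Compound 2 `CCCCCCCCCCc1cc2cn([C@H]3C[C@H](O)[C@@H](CO)O3)c(=O)nc2o1`: > 50000 nM
- Compound 3 `C#CCCCc1cc2cn([C@H]3C[C@H](O)[C@@H](CO)O3)c(=O)nc2o1`: > 200000 nM

Compound 3 has no number, only a limit: the limit of > 200000 nM in this assay, at which 1 of the 3 values shown sits. Compounds 1 and 2 stand at the limit of > 50000 nM in this assay, at which 2 of the 3 values shown sit.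

Compound 4 `C#CCCCCCCc1cc2cn([C@H]3C[C@H](O)[C@@H](CO)O3)c(=O)nc2o1` differs from compound 3 by pent-4-yn-1-yl in place of ethynyl on a saturated chain carbon, three bonds along the chain from an aromatic carbon.

For the measured compounds named here, three measured steps bear on this change: a step that the two limits leave unreadable from compound 1 to compound 3, a step that the two limits leave unreadable from compound 2 to compound 3 and a step that the two limits leave unreadable from compound 1 to compound 2. None has a size that can be read, so they give no direction, and no step beyond the scatter can be expected in this assay. Going by the values given here, with every step so far left unreadable by limits, as in a step that the two limits leave unreadable from compound 2 to compound 3, compound 4 is expected to report a limit as well.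

The estimated change is an at least 2.0-fold lower number from compound 3 to compound 4 (0.30 log units; that floor lies within the scatter).

For compound 4 the expected value is 100000 nM, with an estimated range from 30000 nM to 300000 nM.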

Compound 4, half-maximal cytotoxic concentration: > 200000 nM
Compound 4 was reported as a limit (the forecaster's own chance of this, stated with the estimate: 85%); middle value at least 2.0-fold (0.30 log units) from the limit.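

In this assay compound 4 gives > 200000 nM, which is a limit. The steps from compound 1, compound 2 and compound 3 to compound 4 therefore cannot be read. The compounds shown leave open where any of the four values actually lies, and whether the chain changes it at all.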